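The source may report more compounds than this note shows. Statements on the series, on what has been measured and on what is new or still open speak of the compounds shown alone.

In an ADME assay on microsomes from liver (Rattus norvegicus) for metabolic stability, read by LC-MS, with a stated time of 10 min, tested at 0.5 uM (on this read-out lower numbers stand for a less stable compound and higher numbers for a more stable compound), compound 2 (`CN1CCN(CCCN(C[C@H]2Cc3ccccc3CN2C)[C@H]2CCCc3cccnc32)CC1`) gives 2%, the lowest of the three measured numbers. Compound 1 (`c1cnc2c(c1)CCC[C@@H]2N(CCCN1CCNCC1)Cc1cc2ccccc2cn1`) gives 59% and compound 3 (`c1cnc2c(c1)CN[C@H](CN(CCCN1CCNCC1)[C@H]1CCCc3cccnc31)C2`) gives 87%. Compound 4 (`CN1CCN(CCCN(C[C@H]2Cc3ccccc3CN2)[C@H]2CCCc3cccnc32)CC1`) differs from compound 2 by a single change, hydrogen in place of methyl on an amine nitrogen in a ring. Among the measured compounds shown here, no measured step tests this change directly. For the measured compounds named here, the one step available, a number 28 percentage points higher from compound 1 to compound 3 (beyond the scatter), is a modest move beyond the scatter, but it exchanges a different group and so offers only a rough guide to size. Compound 3, at 87%, also carries hydrogen on an amine nitrogen in a ring, yet it differs from compound 2 in other places too, so its number cannot be assigned to this change alone. A modest upward move is therefore expected, with the estimated step being a number 13 percentage points higher from compound 2 to compound 4 (beyond the scatter). For compound 4 the expected value is 15%, with an estimated range of 3% to 40%.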

Compound 4, percent of the compound remaining: 10%
Compound 4: middle estimate off by 5 percentage points, on the high side; the measured number falls inside the stated range.
By their numbers in this assay, from the lowest: compounds 2 and 4 (each within the scatter of the next); then compound 1; then compound 3.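

In this assay, the direct reading of hydrogen in place of methyl on an amine nitrogen in a ring is a number 8 percentage points higher from compound 2 to compound 4 (within the scatter). At this position, on an amine nitrogen next to the ring atom that bears a large group, the change therefore makes no difference beyond the scatter, and this pair stays low on the read-out. No measured evidence on the result is available to explain it.

As far as these compounds go, whether an ethyl or acetyl group on this same nitrogen would read differently remains open. Also open, from the compounds shown here alone, is how compound 4 would read with hydrogen in place of the methyl on its other ring amine nitrogen, which compound 1 and compound 3 do not carry.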